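The source may hold more compounds than are shown below. What is called first, only, known or untested is meant among the compounds shown, and "the series" means these compounds.

Measured compounds:
- compound 1 `CC(C)n1ncc2c(C(=O)Nc3cc(S(N)(=O)=O)ccc3F)cc(-c3cccs3)nc21`: 25000 nM
- compound 2 `CC(C)n1ncc2c(C(=O)Nc3ccccn3)cc(-c3ccccc3)nc21`: 12500 nM
- compound 3 `CC(C)n1ncc2c(C(=O)N3CCc4cc(F)ccc43)cc(-c3cccs3)nc21`: > 200000 nM

In an ADME assay on LLC-MK2 cells (Macaca mulatta) for cytotoxicity, read by spectrophotometry and crystal violet staining, with a stated time of 4 days (on this read-out higher numbers stand for lower toxicity in this test and lower numbers for higher toxicity in this test), compound 1 gives 25000 nM, the higher of the two numbers, though compound 2 at 12500 nM sits within the scatter of it. Compound 3 reaches only a limit, (the limit of > 200000 nM in this assay, at which 1 of the 3 values shown sits), and no number is known for it. Compound 4 `CC(C)n1ncc2c(C(=O)Nc3cc(C(N)=O)ccc3F)cc(-c3cccs3)nc21` differs from compound 1 by carbamoyl in place of sulfamoyl on an aromatic carbon. Going by the values given here, no measured step of this kind stands beside it, so no size for the move from sulfamoyl to carbamoyl is known; a change within or barely beyond the scatter is expected in this assay, in no fixed direction. Compound 4 is therefore expected to give about 30000 nM, between 10000 nM and 100000 nM, an expected step of a 1.2-fold higher number from compound 1 to compound 4 (0.08 log units; within the scatter).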

Compound 4, half-maximal cytotoxic concentration: 25000 nM
Compound 4: middle estimate off by 1.2-fold (0.08 log units), on the high side; measured number inside the range.
By their numbers in this assay, from the lowest: compounds 2, 1 and 4 (each within the scatter of the next). At a limit, above all of these: compound 3.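

In this assay, carbamoyl in place of sulfamoyl on this aromatic carbon, para to a fluoro group, gives no change at the digits printed from compound 1 to compound 4 (within the scatter). This read-out therefore does not separate the two groups at this position, something compound 1 alone could not show. Nothing measured here accounts for this result. As far as these compounds go, whether an amine or a carboxylic acid on the same carbon would also leave the read-out unmoved remains open. So does whether this change would give the same result on a core carrying a different amide.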